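The compounds below may be only part of what the source reports. "The series", "measured", "known", "first", "only" and "open" are said of these compounds alone.

Measured compounds:
compound 1 `O=C(Nc1cccc(-n2cc(-c3ccncc3)c(-c3ccc(Cl)c(O)c3)n2)c1)Nc1cccc(C(F)(F)F)c1`, 19100 nM
compound 2 `COc1cc(-c2nn(-c3cccc(NC(=O)Nc4cccc(C(F)(F)F)c4)c3)cc2-c2ccncc2)ccc1Cl`, 2310 nM

In a functional assay on UACC-257 cells (Homo sapiens) for inhibition, read by sulforhodamine B assay, with a stated time of 48 h (a lower number here means a stronger inhibitor of growth, a higher number a weaker inhibitor of growth), compound 1 gives the higher of the two numbers; the step of an 8.3-fold lower number from compound 1 to compound 2 (0.92 log units; beyond the scatter) comes from a change at the phenol, not at the urea end. Compound 3 `O=C(Nc1cccc(-n2cc(-c3ccncc3)c(-c3ccc(Cl)c(O)c3)n2)c1)Nc1ccc(Cl)c(C(F)(F)F)c1` differs from compound 1 by chloro in place of hydrogen on an aromatic carbon. No measured step touches this part of the molecule, so nothing shown bears on it directly. The expectation for compound 3 is therefore anchored on compound 1 with wide uncertainty, a step of a 1.6-fold lower number from compound 1 to compound 3 (0.20 log units; within the scatter) in this assay being estimated, most likely a number close to or somewhat lower than that of compound 1. Compound 3 is expected to give about 12000 nM, within 3000 nM to 40000 nM.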

Compound 3, concentration for total growth inhibition: 2100 nM
For compound 3 the middle estimate is 5.7-fold (0.76 log units) above the measured one; the whole stated range lies above it.
By their numbers in this assay, from the lowest: compounds 3 and 2 (each within the scatter of the next); then compound 1.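

In this assay, chloro in place of hydrogen, ortho to the trifluoromethyl group, gives a 9.1-fold lower number from compound 1 to compound 3 (0.96 log units; beyond the scatter) and so shows that the urea end, untouched by the earlier step at the phenol, also moves the number beyond the scatter. A single added heavy atom on the 3-(trifluoromethyl)phenyl group is enough for this. Nothing available accounts for the step. As far as these compounds go, whether a fluoro group, a methyl group or an amine at this position would act like chloro stays open, as does whether this chloro and the methyl on the phenol oxygen would add up in one molecule.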